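From furan-2-yl to phenyl in compound 4

This account rests on a few compounds, and the source may have more. Where it says the series, first, only, none or still open, it means among the compounds named here.

Measured in a functional assay on A549 cells (Homo sapiens), read by MTT assay, with a stated time of 72 h; on this read-out lower numbers stand for stronger inhibition and higher numbers for weaker inhibition:
- Compound 1 `Cc1nc(N)c2c(-c3ccco3)cn([C@@H]3O[C@H](CO)[C@@H](O)[C@H]3O)c2n1` gives > 20000 nM as a limit of the assay
- Compound 2 `COc1nc(N)nc2c1c(-c1ccco1)cn2[C@@H]1O[C@H](CO)[C@@H](O)[C@H]1O` gives > 20000 nM as a limit of the assay
- Compound 3 `Nc1nc2c(c(-c3ccco3)cn2[C@@H]2O[C@H](CO)[C@@H](O)[C@H]2O)c(=O)[nH]1` gives > 20000 nM as a limit of the assay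

Compound 3 therefore stands with no numerical potency, and its entry of > 20000 nM is a limit and not a number. For the measured compounds named here, the series as a whole offers only the limit of > 20000 nM in this assay, at which 3 of the 3 values shown sit, and no measured step between compounds.

Compound 4 `Nc1nc2c(c(-c3ccccc3)cn2[C@@H]2O[C@H](CO)[C@@H](O)[C@H]2O)c(=O)[nH]1` has phenyl in place of the furan-2-yl of compound 3, on an aromatic carbon of a five-membered aromatic ring with 1 nitrogen, part of a fused or bridged system of two rings. The counted change is phenyl in place of furan-2-yl on an aromatic carbon and nothing else differs.

Resting on the limit of > 20000 nM in this assay, at which 3 of the 3 values shown sit, for all three measured compounds, no gain beyond the scatter is expected in this assay. The expected change is a number no higher from compound 3 to compound 4 (the limit leaves the size open) and it may well go unresolved. Compound 4 is estimated at 20000 nM with an expected range from 8000 nM to 40000 nM and a limit of the assay is again expected.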

Compound 4, half-maximal inhibitory concentration: > 100000 nM
Compound 4: only a limit was reported; the forecaster's own chance of this, stated with the estimate: 80%; middle value at least 5.0-fold (0.69 log units) from the limit.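

In this assay compound 4 gives > 100000 nM, a limit of the assay. For the compounds shown here, compound 3 also stands only as a limit, so no step between compound 3 and compound 4 can be read. The compounds shown leave open whether phenyl and furan-2-yl differ at all in this assay, and none of them carries a numerical potency.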